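The compounds below may be only part of what the source reports. "The series", "measured", "known", "first", "only" and "open" are said of these compounds alone.

Three compounds sharing one core were measured in an assay on CHO cells for binding affinity to metabotropic glutamate receptor 2 (Rattus norvegicus); a higher number here means a weaker inhibitor, a lower number a stronger inhibitor. Compound 1 `N[C@]1(C(=O)O)[C@H]2[C@@H](C[C@H]1OCc1ccccc1Cl)[C@]2(F)C(=O)O` gives 4.99 nM, compound 2 `Nc1cccc(CO[C@@H]2C[C@@H]3[C@H]([C@]2(N)C(=O)O)[C@@]3(F)C(=O)O)c1` gives 15.4 nM, and compound 3 `N[C@]1(C(=O)O)[C@H]2[C@@H](C[C@H]1OCc1cc(Cl)cc(Cl)c1)[C@]2(F)C(=O)O` gives 5.61 nM, the second highest of the three numbers: it sits close to compound 1, while a 2.7-fold lower number from compound 2 to compound 3 (0.44 log units; beyond the scatter) sets it apart from compound 2. Compound 4 `N[C@]1(C(=O)O)[C@H]2[C@@H](C[C@H]1OCc1cc(Cl)ccc1Cl)[C@]2(F)C(=O)O` differs from compound 3 by 2,5-dichlorophenyl in place of 3,5-dichlorophenyl on a saturated chain carbon bound to an oxygen on a saturated carbon. The step that bears most on this is a 1.1-fold higher number from compound 1 to compound 3 (0.05 log units; within the scatter), where a different chlorine pattern on the phenyl changed little; by contrast a 3.1-fold higher number from compound 1 to compound 2 (0.49 log units; beyond the scatter) shows that the larger shift came only with the 3-aminophenyl group. A step within the scatter is therefore expected, namely a 1.1-fold higher number from compound 3 to compound 4 (0.03 log units; within the scatter). Compound 4 is estimated at 6 nM, between 3 nM and 15 nM.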

Compound 4, inhibition constant: 11.8 nM
For compound 4 the middle estimate is 2.0-fold (0.29 log units) below the measured one; the range from low to high includes it.
By their numbers in this assay, from the lowest: compounds 1 and 3 (each within the scatter of the next); then compounds 4 and 2 (each within the scatter of the next).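

In this assay the chlorine pattern on this phenyl does matter, with a 2.1-fold higher number from compound 3 to compound 4 (0.32 log units; beyond the scatter) for two groups made of the same atoms joined differently. Adding a chlorine to the phenyl of compound 1 also counts, with a 2.4-fold higher number from compound 1 to compound 4 (0.37 log units; beyond the scatter) as a modest step, while a 1.3-fold lower number from compound 2 to compound 4 (0.12 log units; within the scatter) stays within the scatter, so the 2,5-dichlorophenyl and 3-aminophenyl groups cannot be told apart here. Nothing at hand gives a reason for these shifts. Open, as far as these compounds go, is how a phenyl carrying a methoxy group or a carboxylic acid would compare at this place.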